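Methylsulfonyl for methylsulfanyl on a trifluoromethyl core

This account rests on a few compounds, and the source may have more. Where it says the series, first, only, none or still open, it means among the compounds named here.

Measured so far in a functional assay on CHO cells for agonist activity at Alpha-2C adrenergic receptor (Homo sapiens); on this read-out lower numbers stand for smaller maximal responses and higher numbers for larger maximal responses:
compound 1 `CS(=O)(=O)c1ccc(Cl)cc1NCC1=NCCN1` gives 81%
compound 2 `CSc1ccc(Cl)cc1NCC1=NCCN1` gives 92%
compound 3 `CSc1ccc(C(F)(F)F)cc1NCC1=NCCN1` gives 45%

Compound 4 `CS(=O)(=O)c1ccc(C(F)(F)F)cc1NCC1=NCCN1` is not yet measured in this assay. It arises from compound 3 by methylsulfonyl in place of methylsulfanyl on an aromatic carbon. The same change, (methylsulfonyl in place of methylsulfanyl on an aromatic carbon), has been made once before and gave a number 11 percentage points lower from compound 2 to compound 1 (beyond the scatter). The cores differ: compound 3 arises from compound 2 by trifluoromethyl in place of chloro on an aromatic carbon, a step of a number 47 percentage points lower from compound 2 to compound 3 (beyond the scatter). The place of the change is para to a chloro group in compound 2 but para to a trifluoromethyl group in compound 3, so the change is of the same kind, not the same. With one earlier instance only, the step from compound 3 to compound 4 is expected to be of similar modest size, a number 10 percentage points lower from compound 3 to compound 4 (within the scatter), resting on a number 11 percentage points lower from compound 2 to compound 1 (beyond the scatter). Compound 4 is therefore estimated at 35%, with a range from 20% to 52%.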

Compound 4, largest response reached (reported as maximum), in percent of the reference or control that the assay uses: 25%
Beside the measured number, compound 4's estimate is 10 percentage points above it; low and high end bracket the measured number.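

In this assay, methylsulfonyl in place of methylsulfanyl gives a number 20 percentage points lower from compound 3 to compound 4 (beyond the scatter), and this step carries from the core of compound 2 to the core of compound 3 without a clear difference: the same change on two cores in this assay, a number 11 percentage points lower (beyond the scatter) from compound 2 to compound 1 and a number 20 percentage points lower (beyond the scatter) from compound 3 to compound 4, 9 percentage points apart, within the scatter of two such steps. Trifluoromethyl in place of chloro gives a number 56 percentage points lower from compound 1 to compound 4 (beyond the scatter), and this step also holds whichever of the two sulfur groups is present: the same change on two cores in this assay, a number 47 percentage points lower (beyond the scatter) from compound 2 to compound 3 and a number 56 percentage points lower (beyond the scatter) from compound 1 to compound 4, 9 percentage points apart, within the scatter of two such steps. The two changes thus behave additively across these four compounds, but this single set does not show that they would do so on other cores or in other assays.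

Still open, from the compounds shown here alone, is whether a methoxy group or a nitrile in place of chloro or trifluoromethyl would fit the same pattern. Also open, going by these compounds, is how an ethylsulfonyl group in place of methylsulfonyl would behave.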